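Cytotoxicity in cardiac cells: acetoxy in place of chloroethoxy

This account rests on a few compounds, and the source may have more. Where it says the series, first, only, none or still open, it means among the compounds named here.

Measured so far:
compound 1, `COc1ccc(Cc2coc3cc(O)ccc3c2=O)cc1`, 32100 nM;
compound 2, `COc1ccccc1Cc1coc2cc(O)ccc2c1=O`, 12700 nM;
compound 3, `COc1ccc(Cc2coc3cc(OCCCl)cc(O)c3c2=O)cc1`, > 100000 nM.

All three were tested in a functional assay on H9c2 cells (Mus musculus) for cytotoxicity against H9c2 (Rattus norvegicus), read by MTT assay, with a stated time of 24 h; a higher number here means that more compound is needed for the effect, a lower number that less compound is needed. Compound 1 gives 32100 nM there, and compound 2 gives 12700 nM. For compound 3 the assay reports only a limit, > 100000 nM, so no number is known for it. Compound 3 therefore stands at the edge of what this assay can report, the point described by the limit of > 100000 nM in this assay, at which 1 of the 3 values shown sits, and the other two compounds sit well inside the measurable range.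

Compound 4 is `COc1ccc(Cc2coc3cc(OC(C)=O)cc(O)c3c2=O)cc1`. It differs from compound 3 in one place: acetyl in place of 2-chloroethyl on an oxygen on an aromatic ring. Among the compounds with values here, no step between two measured compounds matches this change, so nothing measured shows what such an exchange does in this assay.

Given that compound 3 already reached the limit, the step from compound 3 to compound 4 is expected to be small, a number no higher from compound 3 to compound 4 (the limit leaves the size open), with no clear direction beyond the scatter. Compound 4 is therefore estimated at 100000 nM, between 40000 nM and 250000 nM, with a substantial chance that the assay again reports only a limit.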

Compound 4, half-maximal effective concentration: > 100000 nM
Compound 4: only a limit was reported; the forecaster's own chance of this, stated with the estimate: 50%; the middle value lies on the limit itself.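

In this assay compound 4 gives > 100000 nM as a limit only. Within the data shown here, compound 3 likewise gave only a limit, so no step from compound 3 to compound 4 can be read. The compounds shown leave open whether in this assay acetoxy differs at all from 2-chloroethoxy, with both compounds resting on the same boundary: the limit of > 100000 nM in this assay, at which 2 of the 4 values shown sit.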